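The compounds below may be only part of what the source reports. "The series", "measured", "known", "first", "only" and "open" are said of these compounds alone.

Measured so far in a functional assay on cells (Homo sapiens) for inhibition, read by MTT assay, with a stated time of 72 h; a higher number here means a weaker inhibitor, a lower number a stronger inhibitor:
- compound 1 `CCOC(=O)Cn1ncc2c(Nc3ccc(NC(=O)CCl)cc3)ncnc21`: 7.27 ug/mL
- compound 2 `CCOC(=O)Cn1ncc2c(Nc3ccc(NS(=O)(=O)c4ccccc4)cc3)ncnc21`: > 100 ug/mL (a limit)
- compound 3 `CCOC(=O)Cn1ncc2c(Nc3ccc(NC(=O)c4ccccc4)cc3)ncnc21`: > 100 ug/mL (a limit)

Compound 3 gives only a limit, > 100 ug/mL, and no number. This is the limit of > 100 ug/mL in this assay, at which 2 of the 3 values shown sit.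

Next comes compound 4 `CCOC(=O)Cn1ncc2c(Nc3ccc(NC(C)=O)cc3)ncnc21`. The change is methyl in place of phenyl on a carbonyl carbon, or benzamido to acetamido.

The closest measured step is an at least 13-fold higher number from compound 1 to compound 3 (1.13 log units; beyond the scatter), with phenyl in place of chloromethyl on a carbonyl carbon. The step of an at least 13-fold higher number from compound 1 to compound 2 (1.13 log units; beyond the scatter) is also large, while a step that the two limits leave unreadable from compound 2 to compound 3 gives nothing to work with. Taken together, the only measured compound with a number, compound 1 at 7.27 ug/mL, has a group without a ring on that carbonyl carbon, and compound 4 has one too. Methyl is not chloromethyl, however, so only part of that gap is expected to return, and a result at the limit remains quite possible. In this assay the expected change is a moderate move towards a lower number, and the estimated step is an at least 2.2-fold lower number from compound 3 to compound 4 (0.34 log units; beyond the scatter). For compound 4 the estimate is 45 ug/mL, with an expected range of 15 ug/mL to 130 ug/mL.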

Compound 4, half-maximal inhibitory concentration: > 64 ug/mL
Compound 4 ended at the assay's limit (the forecaster's own chance of this, stated with the estimate: 40%); at least 1.4-fold (0.15 log units) between middle value and limit.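

In this assay compound 4 gives only a limit, > 64 ug/mL, so methyl in place of phenyl on the carbonyl carbon yields no readable number. Against compound 1, the change of hydrogen in place of chloro on a saturated chain carbon bound to a carbonyl carbon gives an at least 8.8-fold higher number from compound 1 to compound 4 (0.94 log units; beyond the scatter), so among the compounds shown, the absence of a ring on that carbonyl carbon is not enough for a measured number, and this single change in the chain marks the difference. The steps to compound 4 from the two other compounds held at limits cannot be read, as both ends of each are limits.

The limits leave the order among compound 2, compound 3 and compound 4 open, and they do not show how far any of the three lies from compound 1. On these data alone, it also remains open whether the number seen for compound 1 is specific to chloro or would persist with bromo, hydroxyl, an amine or a longer chain on that saturated chain carbon.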